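The source may hold more compounds than are shown below. What is called first, only, known or untested is meant among the compounds shown, and "the series" means these compounds.

Measured so far in a functional assay on MOLT-4 cells (Homo sapiens) for antiproliferative activity, with a stated time of 48 h (on this read-out higher numbers stand for weaker inhibition and lower numbers for stronger inhibition), for the series:
- compound 1 `C=C(Br)C(=O)Nc1ccc(C(=O)/C=C/c2ccccc2)cc1` gives 500 nM
- compound 2 `C=C(Br)C(=O)Nc1ccc(C(=O)/C=C/c2ccc(OC)cc2)cc1` gives 610 nM
- compound 3 `C=C(Br)C(=O)Nc1ccc(C(=O)/C=C/c2cccc(OC)c2)cc1` gives 1100 nM

Compound 3 stands apart from compound 1 only: a 2.2-fold higher number from compound 1 to compound 3 (0.34 log units; beyond the scatter) is the one gap beyond the scatter, whereas a 1.8-fold higher number from compound 2 to compound 3 (0.26 log units; within the scatter) is not.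

The next compound is compound 4 `C=C(Br)C(=O)Nc1ccc(C(=O)/C=C/c2cccc(OC)c2OC)cc1`, which differs from compound 3 by methoxy in place of hydrogen on an aromatic carbon and so carries methoxy in place of hydrogen on an aromatic carbon, ortho to a large group and ortho to a methoxy group.

Among the compounds with values here, two measured steps involve the same kind of replacement: a 1.2-fold higher number from compound 1 to compound 2 (0.09 log units; within the scatter) and a 2.2-fold higher number from compound 1 to compound 3 (0.34 log units; beyond the scatter) are the only evidence. Just the second lies beyond the scatter, and it is modest. Within the data shown here, no measured compound has two methoxy groups on this ring, so the present step starts from a case the series has not tested. A small move towards a higher number in this assay is therefore expected, possibly none beyond the scatter.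

The expected step is a 1.2-fold higher number from compound 3 to compound 4 (0.07 log units; within the scatter) as a working estimate.

For compound 4 the estimated value is 1300 nM with an expected range from 500 nM to 3300 nM in this assay for now.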

Compound 4, half-maximal inhibitory concentration: 490 nM
Compound 4: the middle estimate sits 2.7-fold (0.42 log units) above what was measured, outside the stated range (below it).
By their numbers in this assay, from the lowest: compounds 4, 1, 2 and 3 (each within the scatter of the next, the first and the last beyond it).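

In this assay, within the data shown here, the methoxy that enters ortho to a large group and ortho to a methoxy group gives a 2.2-fold lower number from compound 3 to compound 4 (0.35 log units; beyond the scatter), the first step of this replacement that goes towards a lower number beyond the scatter. The same replacement therefore carries no fixed size or direction from one core to another: the same change on two cores in this assay, a 1.2-fold higher number (0.09 log units; within the scatter) from compound 1 to compound 2 and a 2.2-fold lower number (0.35 log units; beyond the scatter) from compound 3 to compound 4, 2.7-fold (0.44 log units) apart, beyond the scatter of two such steps. The earlier rise, a 2.2-fold higher number from compound 1 to compound 3 (0.34 log units; beyond the scatter), is met by a step of similar size in the opposite direction once the second methoxy enters, so adding methoxy groups to this ring does not push the number one way.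

Still open, from the compounds shown here alone, is whether a single methoxy ortho to a large group, with no second methoxy on the ring, would also give a lower number, and whether the step belongs to methoxy itself or to any group in that place. A hydroxy group, a fluorine atom or a longer chain such as ethoxy at this carbon would separate these readings, and each would still have to be read against the scatter in this assay.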